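Loss of one hydroxy on the trihydroxyphenyl of compound 1

This account rests on a few compounds, and the source may have more. Where it says the series, first, only, none or still open, it means among the compounds named here.

Compound 1 `O=C(/C=C/c1cc(O)c(O)c(O)c1)c1cc(O)cc(/C=C/c2ccc(O)cc2)c1` is the weakest of the three measured here: in a functional assay (a higher number here means a weaker inhibitor, a lower number a stronger inhibitor), compound 1 gives 10 ug/mL, compound 2 `Oc1cc(/C=C/c2cc(O)c(O)c(O)c2)cc(O)c1O` gives 0.9 ug/mL and compound 3 `Oc1cc(/C=C/c2cc(O)c(O)c(Br)c2)cc(O)c1O` gives 8.1 ug/mL, so compound 1 sits near compound 3 and far from compound 2. Compound 4 `O=C(/C=C/c1ccc(O)c(O)c1)c1cc(O)cc(/C=C/c2ccc(O)cc2)c1` differs from compound 1 by hydrogen in place of hydroxy on an aromatic carbon. Within the data shown here, the only measured step touching the same ring, a 9.0-fold higher number from compound 2 to compound 3 (0.95 log units; beyond the scatter), replaced a hydroxy there with bromo, not hydrogen, yet the hydroxy was lost in both cases. A weakening of similar or somewhat smaller size is therefore expected, with the step of a 2.5-fold higher number from compound 1 to compound 4 (0.40 log units; beyond the scatter). Compound 4 is estimated at 25 ug/mL, with a range from 8 ug/mL to 80 ug/mL.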

Compound 4, half-maximal inhibitory concentration: 9.2 ug/mL
Compound 4: middle estimate off by 2.7-fold (0.43 log units), on the high side, within the range that was stated.
By their numbers in this assay, from the lowest: compound 2; then compounds 3, 4 and 1 (each within the scatter of the next).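

In this assay, the change from 3,4,5-trihydroxyphenyl to 3,4-dihydroxyphenyl gives a 1.1-fold lower number from compound 1 to compound 4 (0.04 log units; within the scatter), so on the core of compound 1 this hydroxy gives way to hydrogen with no change beyond the scatter. The weakening in a 9.0-fold higher number from compound 2 to compound 3 (0.95 log units; beyond the scatter) does not carry over to this pair, although that step brings in bromo rather than hydrogen and sits on a different core. Nothing available explains the contrast between the two steps.

Still open, on these data alone, is whether hydrogen in place of this hydroxy is equally neutral on the core of compound 2. Also open, as far as these compounds go, is how an amine or a methoxy group would read at this position on the core of compound 1.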